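Chloro Addition on Two Cores in a Cell Assay

This account rests on a few compounds, and the source may have more. Where it says the series, first, only, none or still open, it means among the compounds named here.

This account concerns four compounds tested in a functional assay on MCF7 cells (Homo sapiens) for inhibition, read by MTT assay, with a stated time of 48 h; a higher number here means a weaker inhibitor, a lower number a stronger inhibitor. Compound 1 `c1ccc(-c2ccnc3c2c(-c2ccccc2)nn3-c2ccccc2)cc1` gives 28200 nM in this assay. Compound 2 `Clc1ccc(-c2ccnc3c2c(-c2ccccc2)nn3-c2ccccc2)cc1`, which carries the change (chloro in place of hydrogen on an aromatic carbon), gives 61100 nM; the step of a 2.2-fold higher number from compound 1 to compound 2 (0.34 log units; beyond the scatter) is modest but lies beyond the scatter. Compound 3 `O=C(C=CNc1cc(-c2ccccc2)nn1-c1ccccc1)c1ccccc1` is built on a different core; the difference between the two cores is not broken down here. In this assay compound 3 gives 9650 nM, the lowest of the three numbers, and its steps to compound 1 and to compound 2 both lie beyond the scatter.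

Compound 4 `O=C(C=CNc1cc(-c2ccccc2)nn1-c1ccccc1)c1ccc(Cl)cc1` has not yet been measured. Among the compounds with values here, it differs from compound 3 by chloro in place of hydrogen on an aromatic carbon, which is the same change as the one from compound 1 to compound 2, and its place reads word for word the same. Because the measured step of a 2.2-fold higher number from compound 1 to compound 2 (0.34 log units; beyond the scatter) weakened inhibition, a step of about a 2.1-fold higher number from compound 3 to compound 4 (0.32 log units; beyond the scatter) is expected for compound 4, resting on that single precedent alone. Compound 4 is therefore estimated at 20000 nM, with a range from 7000 nM to 55000 nM.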

Compound 4, half-maximal inhibitory concentration: 8070 nM
The estimate for compound 4 lay 2.5-fold (0.39 log units) above the measured number, and the stated range covers the measured number.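

In this assay, the chloro change on the core of compound 3 gives a 1.2-fold lower number from compound 3 to compound 4 (0.08 log units; within the scatter), so the two compounds cannot be told apart in this assay. Set beside the earlier step on the core of compound 1, the new step does not separate from it: the same change on two cores in this assay, a 2.2-fold higher number (0.34 log units; beyond the scatter) from compound 1 to compound 2 and a 1.2-fold lower number (0.08 log units; within the scatter) from compound 3 to compound 4, 2.6-fold (0.41 log units) apart, within the scatter of two such steps. Within the data shown here, this shows no measurable dependence of the change on the core, but it does not show that the change carries over unaltered, since the series offers only one pair on each core, and two such steps can neither confirm a shared effect nor rule out a modest difference between the cores.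

The compounds shown leave open how other groups in the place of chloro, such as fluoro, methoxy, an amine or a carboxylic acid, would read in this assay on either core. They also leave open whether chloro on a different aromatic carbon of these compounds would give steps that agree between the two cores.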